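This account rests on a few compounds, and the source may have more. Where it says the series, first, only, none or still open, it means among the compounds named here.

Working notes on the series. Compound 3 `COc1cc(C(=O)c2cn(-c3ccccc3)cc2-c2ccccc2Cl)cc(OC)c1OC` is the weakest of the three measured compounds in a functional assay on MCF7 cells (Homo sapiens) for cytotoxicity, read by MTT assay, with a stated time of 96 h; a lower number here means a stronger inhibitor, a higher number a weaker inhibitor: compound 3 gives 76 nM, the highest number shown. Compound 1 `COc1cc(C(=O)c2cn(-c3ccc(Br)cc3)cc2-c2ccccc2)cc(OC)c1OC` gives 20 nM and compound 2 `COc1cc(C(=O)c2cn(-c3ccc(N)cc3)cc2-c2ccccc2)cc(OC)c1OC` gives 35 nM; both gaps to compound 3 are beyond the scatter, so compound 3 stands alone at the top. Going by the values given here, the one measured step in the set, a 1.8-fold higher number from compound 1 to compound 2 (0.24 log units; within the scatter), sits on the aryl ring attached to the ring nitrogen and not on the aryl ring carried by the ring carbon.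

Compound 4 `COc1ccc(Br)cc1-c1cn(-c2ccccc2)cc1C(=O)c1cc(OC)c(OC)c(OC)c1` differs from compound 3 by 5-bromo-2-methoxyphenyl in place of 2-chlorophenyl on an aromatic carbon. Among the compounds with values here, no measured pair addresses this aryl ring: compound 3 is the only compound in which it is substituted, and its higher number relative to compound 1 and compound 2 is confounded with a different group on the ring nitrogen. The step from compound 1 to compound 2 therefore says nothing about the direction here, and it was itself within the scatter.

The expectation is accordingly no step beyond the scatter, in either direction, a 1.1-fold lower number from compound 3 to compound 4 (0.04 log units; within the scatter), with wide uncertainty. Compound 4 is estimated at 70 nM, within a range of 25 nM to 200 nM.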

Compound 4, half-maximal inhibitory concentration: 2200 nM
Estimate against measurement, compound 4: 31-fold (1.50 log units) below; the whole stated range lies below it.
By their numbers in this assay, from the lowest: compounds 1 and 2 (each within the scatter of the next); then compound 3; then compound 4.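

The aryl ring on the aromatic carbon, two ring bonds from the ring nitrogen, proves highly sensitive to substitution in this assay: replacing 2-chlorophenyl with 5-bromo-2-methoxyphenyl gives a much weaker inhibitor (a 29-fold higher number from compound 3 to compound 4 (1.46 log units; beyond the scatter)). Going by these compounds alone, the earlier compounds offered no single-place comparison at this position, and their only step, on the aryl ring attached to the ring nitrogen, was small and within the scatter (a 1.8-fold higher number from compound 1 to compound 2 (0.24 log units; within the scatter)). Nothing available bears on the reason for this large rise in the number.

The change removes the chloro group and adds both methoxy and bromo groups at once, so the compounds shown leave open which of these alterations carries the step, and an aryl ring at this position bearing the methoxy group without the bromo group, or the bromo group without the methoxy group, would separate them. Also open, going by these compounds, is how this position responds to other groups on the same aryl ring, such as an amine, a hydroxy group or a carboxylic acid.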